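A hydroxyphenyl swap in a cytotoxicity series

The source may report more compounds than this note shows. Statements on the series, on what has been measured and on what is new or still open speak of the compounds shown alone.

In a functional assay on MCF7 cells (Homo sapiens) for cytotoxicity, read by sulforhodamine B assay, with a stated time of 48 h (a lower number here means a stronger inhibitor, a higher number a weaker inhibitor), compound 2 `COc1ccc(C2C(C#N)=C(/N=C/C=C/c3ccccc3)Oc3nc(Nc4ccc(S(N)(=O)=O)cc4)sc32)cc1` gives 28900 nM, and compound 1 `COc1ccc(C2C(C#N)=C(/N=C/c3ccc(N(C)C)cc3)Oc3nc(Nc4ccc(S(N)(=O)=O)cc4)sc32)cc1` sits alongside it at 36200 nM; the two are within the usual scatter of each other, as a 1.3-fold lower number from compound 1 to compound 2 (0.10 log units; within the scatter) shows. Compound 3 `COc1ccc(C2C(C#N)=C(/N=C/c3ccc(O)cc3)Oc3nc(Nc4ccc(S(N)(=O)=O)cc4)sc32)cc1` differs from compound 2 by 4-hydroxyphenyl in place of 2-phenylethenyl on a carbon with a double bond to nitrogen. Within the data shown here, the only measured step on that carbon, from a 4-(dimethylamino)phenyl to the phenylethenyl, stayed within the scatter, so a further swap there is expected to move the number little in either direction. Compound 3 is therefore estimated at 30000 nM, between 12000 nM and 75000 nM. That estimate means a 1.0-fold higher number from compound 2 to compound 3 (0.02 log units; within the scatter).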

Compound 3, half-maximal inhibitory concentration: 34500 nM
Compound 3: middle estimate off by 1.2-fold (0.06 log units), on the low side; the measured number falls inside the stated range.
By their numbers in this assay, from the lowest: compounds 2, 3 and 1 (each within the scatter of the next).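

Within this assay, the swap to 4-hydroxyphenyl gives a 1.2-fold higher number from compound 2 to compound 3 (0.08 log units; within the scatter) and hydroxy in place of dimethylamino on an aromatic carbon gives a 1.0-fold lower number from compound 1 to compound 3 (0.02 log units; within the scatter) as well. A hydroxy group on the aromatic ring thus joins the earlier groups on this carbon, and all three compounds lie within the scatter of one another. Nothing available explains this flatness. On these data alone, whether a carboxylic acid or a primary amine on that ring would produce a step beyond the scatter remains open. So does whether any change at this position can do so.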